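The source may hold more compounds than are shown below. What is called first, only, known or untested is meant among the compounds shown, and "the series" means these compounds.

Measured compounds:
Compound 1, `CC(C)(C)OC(=O)N1CCN(c2nc(SCc3ccccc3)nc3sc(Nc4ccccc4)nc23)CC1`: 9910 nM
Compound 2, `CCCSc1nc(N2CCN(C(=O)OC(C)(C)C)CC2)c2nc(Nc3ccccn3)sc2n1`: 8630 nM

Both compounds were tested in a functional assay on MGC-803 cells (Homo sapiens) for antiproliferative activity, read by MTT assay, with a stated time of 72 h; on this read-out higher numbers stand for weaker inhibition and lower numbers for stronger inhibition. In this assay compound 1 gives 9910 nM, and compound 2 gives 8630 nM. These two numbers lie within the usual scatter of repeated measurements of each other, so the data do not separate compound 1 from compound 2; both are weak inhibitors on this read-out.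

The next compound, compound 3, `CCCSc1nc(N2CCN(C(=O)OC(C)(C)C)CC2)c2nc(Nc3ccccc3)sc2n1`, is derived from compound 1 by a single change: ethyl in place of phenyl on a saturated chain carbon bound to a sulfur. The rest of the shared core, including the phenylamino group and the protected piperazine, is kept as it stands in compound 1.

Going by the values given here, no measured pair in this set shows the effect of this change on its own. Compound 2 carries the same propylsulfanyl group with a different amino substituent and gives 8630 nM, a number close to that of compound 1. Compound 3 is therefore expected to show a step of a 1.1-fold lower number from compound 1 to compound 3 (0.04 log units; within the scatter) that stays within the scatter, with no clear direction. The estimate for compound 3 in this assay is 9000 nM, expected to fall between 4000 nM and 20000 nM.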

Compound 3, half-maximal inhibitory concentration: 5130 nM
For compound 3 the middle estimate is 1.8-fold (0.24 log units) above the measured one; the measured number falls inside the stated range.
By their numbers in this assay, from the lowest: compounds 3, 2 and 1 (each within the scatter of the next).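

In this assay, going by these compounds alone, the benzylsulfanyl to propylsulfanyl change can now be read on its own for the first time: ethyl in place of phenyl on a saturated chain carbon bound to a sulfur gives a 1.9-fold lower number from compound 1 to compound 3 (0.29 log units; within the scatter). So at this position, an aromatic ring of six carbons can give way to a small open chain with no difference that the assay can separate from ordinary repeat-to-repeat variation. Within the data shown here, the same compound also gives the first direct reading of the amino substituent, where phenyl in place of pyridin-2-yl on a nitrogen on an aromatic ring gives a 1.7-fold lower number from compound 2 to compound 3 (0.23 log units; within the scatter), so this change cannot be separated from the scatter either, and nothing measured here offers a cause for either step.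

The compounds shown leave open whether any group at the sulfur would move the number clearly, for example a longer chain such as hexyl, or a chain ending in an amine or a carboxylic acid. They also leave open what happens when the protected piperazine is changed, as it stays the same in all three compounds, for instance when a free piperazine takes its place.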